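Shared-core series: butoxy replaced by tert-butyl

A few compounds are considered here, and "the series" means these few. Any claim that something is new, unique, unknown or untested is made for them only; others in the source may bear on it.

Measured in an assay on mitochondria from L6 cells (Rattus norvegicus) for activation, with a stated time of 90 min; on this read-out higher numbers stand for an effect only at larger amounts of compound and lower numbers for an effect already at smaller amounts:
compound 1 `O=[N+]([O-])c1cc(Nc2nc3nonc3nc2O)ccc1OC(F)(F)F`: 53500 nM
compound 2 `CCCCOc1cccc(Nc2nc3nonc3nc2O)c1`: 2300 nM

Compound 2 holds the lowest of the two numbers; compound 1 shows a higher number than compound 2, and the gap lies beyond the scatter. Compound 3 `CC(C)(C)c1cccc(Nc2nc3nonc3nc2O)c1` is still to be measured. It differs from compound 2 by tert-butyl in place of butoxy on an aromatic carbon.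

Going by the values given here, no measured pair covers this change, so in this assay the expected step is small, in either direction or none beyond the scatter; the estimated step is a 1.3-fold higher number from compound 2 to compound 3 (0.12 log units; within the scatter). Compound 3 is expected at 3000 nM, within 1000 nM to 9000 nM.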

Compound 3, half-maximal effective concentration: 2200 nM
Estimate against measurement, compound 3: 1.4-fold (0.13 log units) above; low and high end bracket the measured number.
By their numbers in this assay, from the lowest: compounds 3 and 2 (each within the scatter of the next); then compound 1.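

In this assay, going by these compounds alone, tert-butyl in place of butoxy on an aromatic carbon, meta to a large group, leaves the number unchanged within the scatter (a 1.0-fold lower number from compound 2 to compound 3 (0.02 log units; within the scatter)) and this is the first read on that position. The oxygen of butoxy and its unbranched chain are therefore not needed to keep the number at this level, as tert-butyl carries no hydrogen-bond acceptor. Nothing on hand explains this tolerance.

Open, on these data alone, is whether an amine or a carboxylic acid at this place would also stay within the scatter of compound 2. As far as these compounds go, a longer chain such as hexyloxy is equally open.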